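A few compounds are considered here, and "the series" means these few. Any claim that something is new, unique, unknown or untested is made for them only; others in the source may bear on it.

Compound 1 `Cc1cnc(NC(=O)COc2ccc(/C=C3\SC(=O)NC3=O)cc2)s1`: in a functional assay on HepG2 cells (Homo sapiens) for cytotoxicity, read by sulforhodamine B assay, with a stated time of 48 h (on this read-out higher numbers stand for weaker inhibition of growth and lower numbers for stronger inhibition of growth), compound 1 gives < 100000 nM, a limit of the assay and not a number.
Compound 2 `O=C(COc1ccc(/C=C2\SC(=O)NC2=O)cc1)Nc1cccc(C(F)(F)F)c1`: in this assay compound 2 gives < 100000 nM, likewise only a limit.

Both measured values sit at the limit of < 100000 nM in this assay, at which 2 of the 2 values shown sit, so compound 1 stands at the limit and cannot be placed relative to compound 2. Compound 3 `Cc1cc(NC(=O)COc2ccc(/C=C3\SC(=O)NC3=O)cc2)no1` differs from compound 1 by 5-methyl-1,2-oxazol-3-yl in place of 5-methyl-1,3-thiazol-2-yl on an amide-type nitrogen. Going by the values given here, no step between measured compounds is known, and for this change no size of step in this assay is expected beyond the scatter. Compound 3 is therefore expected to give 40000 nM, most likely again only a limit, within 8000 nM to 100000 nM. The expected step is a step that the limit leaves unreadable from compound 1 to compound 3.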

Compound 3, concentration for 50% growth inhibition: < 100000 nM
Compound 3 gave a limit, no number; the forecaster's own chance of this, stated with the estimate: 70%; the middle value lies beyond the limit too.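

No step can be read from compound 1 to compound 3 in this assay, as each gives only a limit of the assay and not a number: the limit of < 100000 nM in this assay, at which 3 of the 3 values shown sit.

Going by these compounds, how strongly compound 1, compound 2 and compound 3 actually inhibit growth stays open, as does whether the 5-methyl-1,2-oxazol-3-yl for 5-methyl-1,3-thiazol-2-yl exchange changes it.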